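The source may report more compounds than this note shows. Statements on the series, on what has been measured and on what is new or still open speak of the compounds shown alone.

Measured in a functional assay on A549 cells (Homo sapiens) for antiproliferative activity, read by sulforhodamine B assay, with a stated time of 48 h; on this read-out lower numbers stand for stronger inhibition of growth and higher numbers for weaker inhibition of growth:
Compound 1 `Cc1cc2c(cc1C)C(Cl)=C(c1nnc(S)n1-c1ccccc1)CCC2`: 1490 nM
Compound 2 `S=c1[nH]nc(C2=C(Cl)c3ccccc3CCC2)o1`: 4960 nM
Compound 3 `ClC1=C(c2nnc(-c3ccccc3)o2)CCCc2ccccc21`: 2270 nM

Compound 3, at 2270 nM, lies within the scatter of compound 1, at 1490 nM. Its number is lower than that of compound 2, at 4960 nM, and that gap is beyond the scatter.

Compound 4 `Cc1ccc(-c2nnc(C3=C(Cl)c4ccccc4CCC3)o2)cc1` has not yet been measured. It differs from compound 3 by one substitution, phenyl to 4-methylphenyl, with methyl in place of hydrogen on an aromatic carbon.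

Within the data shown here, no measured pair isolates that change, so the expectation starts from compound 3 at 2270 nM. No shift beyond the scatter is expected in this assay, and no firm direction can be drawn from these data. The expected change is small, and the estimated step of a 1.1-fold lower number from compound 3 to compound 4 (0.03 log units; within the scatter) stays within the scatter.

For compound 4 the estimated value is 2100 nM, with an expected range of 900 nM to 4800 nM.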

Compound 4, concentration for 50% growth inhibition: 3420 nM
Compound 4: the middle estimate sits 1.6-fold (0.21 log units) below what was measured; the measured number falls inside the stated range.
By their numbers in this assay, from the lowest: compounds 1, 3, 4 and 2 (each within the scatter of the next, the first and the last beyond it).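

In this assay, among these compounds, methyl in place of hydrogen on an aromatic carbon, para to a large group, gives a 1.5-fold higher number from compound 3 to compound 4 (0.18 log units; within the scatter) and is the first change that can be read on its own. The phenyl ring of compound 3 therefore accepts this single added carbon at that place without a shift beyond the scatter, so the methyl gives no measurable gain or loss here. No measurement on hand bears on the reason for this small step.

One small group at one place says little about the reach of this position: an amine, a carboxylic acid or a longer chain there could still move the number beyond the scatter. On these data alone, whether methyl behaves the same way at other places on this phenyl ring also remains open.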